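Swapping One Para Substituent for Another

The compounds below may be only part of what the source reports. "The series", "measured", "known", "first", "only" and "open" are said of these compounds alone.

Of the compounds shown here, three sharing one core have been tested in a functional assay on MCF7 cells (Homo sapiens) for antiproliferative activity, read by MTT assay, with a stated time of 48 h; a lower number here means a stronger inhibitor, a higher number a weaker inhibitor. Compound 1 `O=c1cc(-n2cc(COc3ccccc3)nn2)c2cc(Br)ccc2o1` gives 1720 nM. Compound 2 `CCc1ccc(OCc2cn(-c3cc(=O)oc4ccc(Br)cc34)nn2)cc1` gives 12700 nM, and compound 3 `O=c1cc(-n2cc(COc3ccc(C(F)(F)F)cc3)nn2)c2cc(Br)ccc2o1` gives 11400 nM. Among these three numbers compound 3 stands second highest: its nearest neighbour is reached by the step of a 1.1-fold lower number from compound 2 to compound 3 (0.05 log units; within the scatter), which is within the scatter, while the step of a 6.6-fold higher number from compound 1 to compound 3 (0.82 log units; beyond the scatter) lies beyond it, as does a 7.4-fold higher number from compound 1 to compound 2 (0.87 log units; beyond the scatter).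

Compound 4 `COC(=O)c1ccc(OCc2cn(-c3cc(=O)oc4ccc(Br)cc34)nn2)cc1` differs from compound 3 in one place: methoxycarbonyl in place of trifluoromethyl on an aromatic carbon. The step that bears most directly on this is a 1.1-fold lower number from compound 2 to compound 3 (0.05 log units; within the scatter), where one group at this same position was exchanged for another without a shift beyond the scatter. The two steps starting from compound 1 show that placing a group there at all raised the number modestly, but compound 2 and compound 3 each already carry one. In this assay a step of no size beyond the scatter is therefore expected, a 1.1-fold lower number from compound 3 to compound 4 (0.06 log units; within the scatter). Compound 4 is estimated at 10000 nM, within a range from 3000 nM to 30000 nM.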

Compound 4, half-maximal inhibitory concentration: 3130 nM
Compound 4: middle estimate off by 3.2-fold (0.50 log units), on the high side; the measured number falls inside the stated range.
By their numbers in this assay, from the lowest: compounds 1 and 4 (each within the scatter of the next); then compounds 3 and 2 (each within the scatter of the next).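

At this position, the choice of group matters, which the pair of ethyl and trifluoromethyl could not show, since those two gave numbers within the scatter of each other. In this assay methoxycarbonyl in place of trifluoromethyl gives a 3.6-fold lower number from compound 3 to compound 4 (0.56 log units; beyond the scatter) and methoxycarbonyl in place of ethyl gives a 4.1-fold lower number from compound 2 to compound 4 (0.61 log units; beyond the scatter) while the step from hydrogen is a 1.8-fold higher number from compound 1 to compound 4 (0.26 log units; within the scatter) so a group here need not raise the number, even though the groups in compound 2 and compound 3 do. Nothing measured here accounts for this difference between the groups.

The compounds shown leave open where an amine, a carboxylic acid or a longer chain at this position would fall. They also leave open whether an amide would match methoxycarbonyl or fall closer to ethyl and trifluoromethyl.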